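Replacing Isopropyl with Cyclopropyl in Compound 2

A few compounds are considered here, and "the series" means these few. Any claim that something is new, unique, unknown or untested is made for them only; others in the source may bear on it.

In an in vitro ADME assay on microsomes from liver (Homo sapiens) for pharmacokinetics, read by LC-MS, with a stated time of 10 min, tested at 1 uM (on this read-out higher numbers stand for fast clearance and lower numbers for slow clearance), compound 1 (`CN1C[C@H](C(=O)Nc2ccc(F)cc2)[C@@H](c2ccc(/C=C/C(=O)Nc3ccccc3N)cc2)C1`) gives 5 mL/min/kg and compound 2 (`CC(C)c1ccc(NC(=O)[C@H]2CN(C)C[C@@H]2c2ccc(/C=C/C(=O)Nc3ccccc3N)cc2)cc1`) gives 10 mL/min/kg (two values within the scatter of each other). Compound 3 (`CN1C[C@H](C(=O)Nc2ccc(C3CC3)cc2)[C@@H](c2ccc(/C=C/C(=O)Nc3ccccc3N)cc2)C1`) differs from compound 2 by one change (cyclopropyl in place of isopropyl on an aromatic carbon): cyclopropyl in place of isopropyl on an aromatic carbon. Going by the values given here, the only measured step at this place (a 2.0-fold higher number from compound 1 to compound 2 (0.30 log units; within the scatter)) lies within the scatter. The estimated step of a 1.3-fold lower number from compound 2 to compound 3 (0.10 log units; within the scatter) therefore stays within the scatter in this assay and has no firm direction. Compound 3 is expected at 8 mL/min/kg (estimated range 4 mL/min/kg to 17 mL/min/kg).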

Compound 3, clearance: 12 mL/min/kg
Beside the measured number, compound 3's estimate is 1.5-fold (0.18 log units) below it; low and high end bracket the measured number.
By their numbers in this assay, from the lowest: compounds 1, 2 and 3 (each within the scatter of the next, the first and the last beyond it).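

In this assay cyclopropyl in place of isopropyl gives a 1.2-fold higher number from compound 2 to compound 3 (0.08 log units; within the scatter) and so does not set these two groups apart. Cyclopropyl in place of fluoro gives a 2.4-fold higher number from compound 1 to compound 3 (0.38 log units; beyond the scatter) and is the only step at this position that clears the scatter, though only modestly. No available measurement explains either step.

On these data alone, whether an amine or a carboxylic acid on this aromatic carbon would shift clearance further remains open. So does whether these steps would hold if another part of the shared core were changed.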